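Compound 4: replacing the phenyl group of compound 3

This account rests on a few compounds, and the source may have more. Where it says the series, first, only, none or still open, it means among the compounds named here.

Measured in a functional assay on MDA-MB-231 cells (Homo sapiens) for antiproliferative activity, read by MTT assay, with a stated time of 48 h; a higher number here means a weaker inhibitor, a lower number a stronger inhibitor:
- compound 1 `CN1CCN(c2ccc(-c3cc4c(N5CCN(S(=O)(=O)N6CCCCC6)CC5)ncnc4s3)cc2)CC1`: 8130 nM
- compound 2 `CN1CCN(c2ccc(-c3cc4c(N5CCN(C(=O)Nc6ccc(C#N)cc6)CC5)ncnc4s3)cc2)CC1`: 3930 nM
- compound 3 `CN1CCN(c2ccc(-c3cc4c(N5CCN(C(=O)Nc6cccc(F)c6)CC5)ncnc4s3)cc2)CC1`: 13200 nM

In this assay, compound 3 stands at 13200 nM. The data show a 1.6-fold higher number from compound 1 to compound 3 (0.21 log units; within the scatter), so those two values cannot be ranked. They also show a 3.4-fold higher number from compound 2 to compound 3 (0.53 log units; beyond the scatter), which separates those two compounds.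

The next molecule, compound 4 `CN1CCN(c2ccc(-c3cc4c(N5CCN(C(=O)Nc6cc(C(F)(F)F)ccc6F)CC5)ncnc4s3)cc2)CC1`, carries 2-fluoro-5-(trifluoromethyl)phenyl in place of 3-fluorophenyl on an amide-type nitrogen.

For the measured compounds named here, the step from compound 2 is the best guide, as it is the only measured swap of the group on that same nitrogen. It shows that such a swap can shift the number modestly, but a single step sets no rule for direction. Compound 2, with its different ring at that nitrogen, reaches 3930 nM, so a modest move toward a lower number seems more likely than a rise, though no real change remains possible. The expected size is a 1.7-fold lower number from compound 3 to compound 4 (0.22 log units; within the scatter). For compound 4 the estimated value is 8000 nM, with an expected range of 2500 nM to 25000 nM.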

Compound 4, half-maximal inhibitory concentration: 9090 nM
Compound 4: middle estimate off by 1.1-fold (0.06 log units), on the low side; the range from low to high includes it.
By their numbers in this assay, from the lowest: compound 2; then compounds 1, 4 and 3 (each within the scatter of the next).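

In this assay, moving to 2-fluoro-5-(trifluoromethyl)phenyl on the amide-type nitrogen gives a 1.5-fold lower number from compound 3 to compound 4 (0.16 log units; within the scatter) and so leaves compound 3 and compound 4 unranked. Set against the 4-cyanophenyl group, the same ring gives a 2.3-fold higher number from compound 2 to compound 4 (0.36 log units; beyond the scatter) and so shows that compound 2 stands modestly apart from a second fluorinated ring, not only from the 3-fluorophenyl of compound 3. Nothing available here offers an explanation for these steps.

The compounds shown leave open whether the separation of compound 2 belongs to its nitrile or to some other feature of its ring. Going by these compounds, how an amine or a carboxylic acid on that phenyl ring, or a longer chain in place of the ring, would read in this assay also remains unknown.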